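Extending the Chain End with an Ethyl Group

A few compounds are considered here, and "the series" means these few. Any claim that something is new, unique, unknown or untested is made for them only; others in the source may bear on it.

Compound 1 `CCCCCCCCCCCCc1ccc(CO[C@@H]2CN[C@@H](CO)C2)cc1` and compound 2 `CCCCCCCCCCCCCCc1ccc(CO[C@@H]2CN[C@@H](CO)C2)cc1` share one core and differ by ethyl in place of hydrogen on a saturated chain carbon, ten or more bonds along the chain from an aromatic carbon. In a functional assay on FL5.12 cells (Mus musculus) for cytotoxicity, read by flow cytometry, with a stated time of 48 h (on this read-out lower numbers stand for stronger inhibition and higher numbers for weaker inhibition), compound 1 gives 10100 nM and compound 2 gives 10500 nM. That step is a 1.0-fold higher number from compound 1 to compound 2 (0.02 log units; within the scatter). Compound 3 `CCCCCCCCCC/C=C/c1ccc(CO[C@H]2CN[C@H](CO)C2)cc1` rests on a different core; the difference between the two cores is not broken down here. In this assay compound 3 gives 2400 nM, the lowest of the three numbers, beyond the scatter from both others. Compound 4 `CCCCCCCCCCCC/C=C/c1ccc(CO[C@H]2CN[C@H](CO)C2)cc1` is not yet measured and differs from compound 3 by ethyl in place of hydrogen on a saturated chain carbon, ten or more bonds along the chain from a double-bonded chain carbon. This is the same kind of change as that between compound 1 and compound 2, though here the place is counted from a double-bonded chain carbon rather than from an aromatic carbon. Compound 4 is expected to show a step of a 1.1-fold higher number from compound 3 to compound 4 (0.03 log units; within the scatter), an expectation that rests on the earlier step of a 1.0-fold higher number from compound 1 to compound 2 (0.02 log units; within the scatter). Compound 4 is therefore estimated at 2600 nM in this assay, likely between 1200 nM and 5500 nM.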

Compound 4, half-maximal inhibitory concentration: 7300 nM
The estimate for compound 4 lay 2.8-fold (0.45 log units) below the measured number; measured number outside the range, above it.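

In this assay the same ethyl in place of hydrogen gives a 3.0-fold higher number from compound 3 to compound 4 (0.48 log units; beyond the scatter), which means weaker inhibition on this core. The change therefore does not carry over with the same size from one core to the other, as the two steps differ: the same change on two cores in this assay, a 1.0-fold higher number (0.02 log units; within the scatter) from compound 1 to compound 2 and a 3.0-fold higher number (0.48 log units; beyond the scatter) from compound 3 to compound 4, 2.9-fold (0.47 log units) apart, beyond the scatter of two such steps

With a single pair on each core, this shows only that the size of the step depends on the core in these four compounds; it does not show which part of the difference between the cores matters, or whether the gap would hold for other pairs. The compounds shown leave open how a longer chain would behave on either core. They also leave open how a carboxylic acid in place of the ethyl would compare.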